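This account rests on a few compounds, and the source may have more. Where it says the series, first, only, none or still open, it means among the compounds named here.

Measured so far in a functional assay on U-87MG ATCC cells (Homo sapiens) for inhibition; a lower number here means a stronger inhibitor, a higher number a weaker inhibitor:
compound 1 `COc1cc(/C=C/C(=O)c2cccc(NC(=O)c3cc(Cl)cc(Cl)c3)c2)ccc1O`: > 50 ug/mL, a limit of the assay rather than a number.
compound 2 `COc1cc(/C=C/C(=O)c2cccc(N)c2)ccc1O`: 7.71 ug/mL.
compound 3 `COC(=O)C(=O)Nc1cccc(C(=O)/C=C/c2ccc(O)c(OC)c2)c1`: 12.2 ug/mL.

Compound 2 has the lowest of the two numbers in this assay; the nearest is compound 3, and the step of a 1.6-fold higher number from compound 2 to compound 3 (0.20 log units; within the scatter) lies within the scatter, so the two cannot be ordered. Compound 1 sits at the limit of > 50 ug/mL in this assay, at which 1 of the 3 values shown sits, and the steps of an at least 6.4-fold lower number from compound 1 to compound 2 (0.81 log units; beyond the scatter) and an at least 4.0-fold lower number from compound 1 to compound 3 (0.61 log units; beyond the scatter) are both beyond the scatter.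

Compound 4 `CCCC(=O)Nc1cccc(C(=O)/C=C/c2ccc(O)c(OC)c2)c1` differs from compound 2 by propylcarbonyl in place of hydrogen on a nitrogen on an aromatic ring. Within the data shown here, two measured steps bear on acylation of this nitrogen: a 1.6-fold higher number from compound 2 to compound 3 (0.20 log units; within the scatter), within the scatter, where the entering group carries no ring; and an at least 6.4-fold lower number from compound 1 to compound 2 (0.81 log units; beyond the scatter), where removal of the (3,5-dichlorophenyl)carbonyl lowers the number by at least a modest step. Propylcarbonyl, like the group entering in compound 3, has no ring, so a change near the scatter is expected, at most a modest rise, with a 1.8-fold higher number from compound 2 to compound 4 (0.26 log units; within the scatter). Compound 4 is therefore estimated at 14 ug/mL in this assay, within 6 ug/mL to 40 ug/mL.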

Compound 4, half-maximal inhibitory concentration: 5.56 ug/mL
For compound 4 the middle estimate is 2.5-fold (0.40 log units) above the measured one; measured number below the stated range.
By their numbers in this assay, from the lowest: compounds 4, 2 and 3 (each within the scatter of the next, the first and the last beyond it). At a limit, above all of these: compound 1.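

In this assay, propylcarbonyl, a group with no ring, leaves the number on this nitrogen within the scatter of the free amino compound (a 1.4-fold lower number from compound 2 to compound 4 (0.14 log units; within the scatter)). Among these compounds, the acyl groups with no ring are now separated for the first time, with propyl in place of methoxycarbonyl on the carbonyl carbon giving a modest step beyond the scatter (a 2.2-fold lower number from compound 3 to compound 4 (0.34 log units; beyond the scatter)), although compound 2 stays within the scatter of both compound 3 and compound 4. Propyl in place of 3,5-dichlorophenyl gives the widest step in the series (an at least 8.9-fold lower number from compound 1 to compound 4 (0.95 log units; beyond the scatter)), but this is a bound only, and the value of compound 1 is a limit rather than a number: (the limit of > 50 ug/mL in this assay, at which 1 of the 4 values shown sits).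

As far as these compounds go, whether a longer chain on the carbonyl carbon would stay near compound 4 remains open. Also open, from the compounds shown here alone, is whether an unsubstituted phenyl would behave like propyl or like 3,5-dichlorophenyl, which would separate the ring from its chlorines.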